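A few compounds are considered here, and "the series" means these few. Any claim that something is new, unique, unknown or untested is made for them only; others in the source may bear on it.

Working notes on the series. In a functional assay on HL-60 cells (Homo sapiens) for inhibition, read by sulforhodamine B assay, with a stated time of 48 h (a lower number here means a stronger inhibitor of growth, a higher number a weaker inhibitor of growth), compound 1 (`NC(=O)c1cc(Br)ccc1NC(=O)/C=C/c1ccccc1`) gives 346 nM and compound 2 (`NC(=O)c1cc(I)ccc1NC(=O)/C=C/c1ccccc1`) gives 54.2 nM. For the measured compounds named here, compound 2 therefore holds the lower of the two numbers so far. Next is compound 3 (`NC(=O)c1cc(I)ccc1NC(=O)/C=C/c1ccccc1Cl`), which differs from compound 2 by chloro in place of hydrogen on an aromatic carbon, phenyl to 2-chlorophenyl, ortho to a large group. Going by the values given here, the only measured step is a 6.4-fold lower number from compound 1 to compound 2 (0.81 log units; beyond the scatter), for iodo in place of bromo on an aromatic carbon. Among the compounds with values here, it bears only loosely on this change, since no measured compound carries a substituent on the phenyl. The data give no direction, so no shift beyond the scatter is expected in this assay, although that step argues for a wide range. The expected result is a 1.3-fold higher number from compound 2 to compound 3 (0.11 log units; within the scatter). For compound 3 the estimate is 70 nM, with an expected range of 20 nM to 230 nM.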

Compound 3, concentration for 50% growth inhibition: 165 nM
Compound 3: middle estimate off by 2.4-fold (0.37 log units), on the low side; the measured number falls inside the stated range.
By their numbers in this assay, from the lowest: compound 2; then compound 3; then compound 1.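

In this assay, chloro in place of hydrogen on an aromatic carbon gives a 3.0-fold higher number from compound 2 to compound 3 (0.48 log units; beyond the scatter). For the compounds shown here, this is the first measured change on the phenyl, and it shows that the place ortho to a large group is not indifferent to substitution: with iodo on the shared core, hydrogen there gives the lower number and chloro the higher one. Nothing measured on these compounds accounts for this shift.

This single step gives a direction for chloro only, and it leaves open whether fluoro, methyl or methoxy at the same place would give a similar shift. Also open, from the compounds shown here alone, are how chloro behaves on other carbons of the phenyl and whether the same step would appear with bromo, as in compound 1, rather than iodo.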